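The source may hold more compounds than are shown below. What is called first, only, known or untested is meant among the compounds shown, and "the series" means these compounds.

In a functional assay on A2780 cells (Homo sapiens) for inhibition, read by sulforhodamine B assay (on this read-out higher numbers stand for weaker inhibition of growth and lower numbers for stronger inhibition of growth), compound 1 (`Oc1ccc(-c2ccc(-c3ccc(-c4nc5ccccc5[nH]4)cc3)cc2)cc1`) gives 36000 nM and compound 2 (`Oc1cccc2[nH]c(-c3ccc(-c4ccc(-c5ccc(F)cc5)cc4)cc3)nc12`) gives 41200 nM, so compound 2 stands within the scatter of compound 1. Compound 3 (`Oc1ccc(-c2ccc(-c3ccc(-c4nc5c(O)cccc5[nH]4)cc3)cc2)cc1`) differs from compound 2 by one change: hydroxy in place of fluoro on an aromatic carbon, para to a large group. Compound 1 also ends in 4-hydroxyphenyl and gives 36000 nM, which offers no ground for expecting a large step. The expected step of a 1.4-fold lower number from compound 2 to compound 3 (0.14 log units; within the scatter) stays within the scatter, with no firm direction. For compound 3 the estimated value is 30000 nM, with an expected range of 10000 nM to 70000 nM.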

Compound 3, concentration for 50% growth inhibition: 2920 nM
For compound 3 the middle estimate is 10-fold (1.01 log units) above the measured one; the whole stated range lies above it.
By their numbers in this assay, from the lowest: compound 3; then compounds 1 and 2 (each within the scatter of the next).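

In this assay, going from 4-fluorophenyl to 4-hydroxyphenyl gives a 14-fold lower number from compound 2 to compound 3 (1.15 log units; beyond the scatter), and adding a hydroxy group to the shared core gives a 12-fold lower number from compound 1 to compound 3 (1.09 log units; beyond the scatter). Compound 1 and compound 2 each carry one of the two hydroxy groups of compound 3 and stand within the scatter of each other, so among these compounds only the one carrying both reaches the low number. Nothing measured here explains the size of these steps. From the compounds shown here alone, whether an amine or a methoxy group in place of the hydroxy of the 4-hydroxyphenyl end would keep this low number remains open.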